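A few compounds are considered here, and "the series" means these few. Any claim that something is new, unique, unknown or untested is made for them only; others in the source may bear on it.

Compound 1 `O=C(O)CCCCC(CCSC(=O)c1ccccc1)SC(=O)c1ccccc1`: 86.7%
Compound 2 `CC(=O)SCCC(CCCCC(=O)Nc1ccccc1)SC(C)=O`: 22.3%

Both were tested in a functional assay on HO8910 cells (Homo sapiens) for inhibition, read by MTT assay, with a stated time of 24 h, tested at 100 ug/mL; on this read-out higher numbers stand for more inhibition of growth at the one concentration tested and lower numbers for less inhibition of growth. Compound 2, at 22.3%, is the lower of the two, and the gap between it and compound 1, at 86.7%, lies well beyond the usual scatter. Compound 3 `CC(=O)SCCC(CCCCC(=O)Nc1cccc(Cl)c1)SC(C)=O` has not yet been measured. It differs from compound 2 by chloro in place of hydrogen on an aromatic carbon, meta to a large group: chloro in place of hydrogen on an aromatic carbon. Within the data shown here, no measured pair shows this change, so the expectation is loose: a modest rise in this assay, possibly none beyond the scatter. The expected step is a number 7.7 percentage points higher from compound 2 to compound 3 (within the scatter). For compound 3 the estimate is 30%, with an expected range from 14% to 50%.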

Compound 3, percent growth inhibition at one concentration: 38.2%
Compound 3: the middle estimate sits 8.2 percentage points below what was measured; low and high end bracket the measured number.
By their numbers in this assay, from the lowest: compound 2; then compound 3; then compound 1.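

In this assay, chloro in place of hydrogen on the aromatic ring, meta to a large group, gives a number 15.9 percentage points higher from compound 2 to compound 3 (beyond the scatter). This is the first change in a single place among these compounds, and it shows that this ring position can alter growth inhibition, though only modestly. No available data explain why this step occurs. Going by these compounds, whether a methoxy or a nitrile group at this position would give a similar step remains open, as does the effect of chloro elsewhere on the ring.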